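Fluoroindole propyl series: changing the chain end group

This account rests on a few compounds, and the source may have more. Where it says the series, first, only, none or still open, it means among the compounds named here.

Measured so far in an assay on isolated protein for inhibition of Myeloperoxidase (Homo sapiens), read by ELISA, with a stated time of 5 min; a lower number here means a stronger inhibitor, a higher number a weaker inhibitor:
compound 1, `CNC(=O)CCCc1c[nH]c2ccc(F)cc12`, gives 95 nM
compound 2, `N#CSCCCc1c[nH]c2ccc(F)cc12`, gives 23 nM

Compound 2 holds the lowest of the two numbers shown; its only neighbour is compound 1, and the single step between them, a 4.1-fold lower number from compound 1 to compound 2 (0.62 log units; beyond the scatter), places compound 2 beyond the scatter from it. Compound 3, `ONCCCc1c[nH]c2ccc(F)cc12`, is not yet measured. It differs from compound 2 by hydroxyamino in place of cyanosulfanyl on a saturated chain carbon, three bonds along the chain from an aromatic carbon. Within the data shown here, the one measured step at this chain position exchanged a different pair of groups, so it shows only that the chain end can move the number by a modest amount in either direction; nothing here tells which way a hydroxyamino group will go. The change from compound 2 to compound 3 is therefore expected to stay close to the scatter, a 1.7-fold higher number from compound 2 to compound 3 (0.24 log units; within the scatter), with wide uncertainty. For compound 3 the estimate in this assay is 40 nM, in the range 10 nM to 160 nM.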

Compound 3, half-maximal inhibitory concentration: 21 nM
Compound 3: middle estimate off by 1.9-fold (0.28 log units), on the high side; the range from low to high includes it.
By their numbers in this assay, from the lowest: compounds 3 and 2 (each within the scatter of the next); then compound 1.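

Replacing cyanosulfanyl with hydroxyamino on a saturated chain carbon, three bonds along the chain from an aromatic carbon, gives a 1.1-fold lower number from compound 2 to compound 3 (0.04 log units; within the scatter) in this assay, even though the entering group has 2 hydrogen-bond donors and the leaving group has 0. Across this one pair, neither that count nor the change from 3 heavy atoms to 2 separates the numbers. Methylcarbamoyl is now set apart from two different end groups, with a 4.5-fold lower number from compound 1 to compound 3 (0.66 log units; beyond the scatter) adding to the earlier step, but the data give no reason for this gap.

As far as these compounds go, it remains open whether an amine or a carboxylic acid at this chain position would fall level with compound 2 and compound 3 or with compound 1. A longer chain carrying hydroxyamino or cyanosulfanyl also remains to be placed against these values.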